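Methyl on the pyrrole nitrogen: a small change tested

A few compounds are considered here, and "the series" means these few. Any claim that something is new, unique, unknown or untested is made for them only; others in the source may bear on it.

Measured so far:
compound 1 `COc1ccc(Cc2nnc3n2NC(c2ccc([N+](=O)[O-])o2)S3)cc1OC` — in a functional assay on the whole organism (strain Wistar Albino) for inhibition, with Rattus norvegicus as the target, read by paw edema, with a stated time of 2 h, at a dose of 20 mg/kg (on this read-out higher numbers stand for more inhibition at the one dose given (going by the name of the read-out) and lower numbers for less inhibition), compound 1 gives 17.6%
compound 2 `COc1ccc(Cc2nnc3n2NC(c2ccc[nH]2)S3)cc1OC` — in this assay compound 2 gives 15.9%

Compound 2 has the lower of the two numbers, though the step of a number 1.7 percentage points lower from compound 1 to compound 2 (within the scatter) lies within the scatter, so the two compounds cannot be ranked. Compound 3 `COc1ccc(Cc2nnc3n2NC(c2cccn2C)S3)cc1OC` differs from compound 2 by methyl in place of hydrogen on an aromatic nitrogen. Going by the values given here, the only measured step swapped one ring for another and does not touch the pyrrole nitrogen, so no step bears directly on this change. With so small an addition, no move beyond the scatter is expected in this assay, that is, a step of a number 0.1 percentage points higher from compound 2 to compound 3 (within the scatter) is expected. Compound 3 is therefore estimated at 16%, within 7% to 26%.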

Compound 3, a percentage reported as inhibition, in the whole organism at one dose (the size of the read-out at that dose, not a potency): 15.8%
The estimate for compound 3 lay 0.2 percentage points above the measured number; low and high end bracket the measured number.
By their numbers in this assay, from the lowest: compounds 3, 2 and 1 (each within the scatter of the next).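

In this assay, the step for methyl in place of hydrogen on the aromatic nitrogen is a number 0.1 percentage points lower from compound 2 to compound 3 (within the scatter), so compounds 2 and 3 cannot be told apart and this position accepts the methyl without a readable difference. With 1-methyl-1H-pyrrol-2-yl in place of 5-nitrofuran-2-yl, the step is a number 1.8 percentage points lower from compound 1 to compound 3 (within the scatter), so this ring swap also gives no readable difference. No independent measurement here bears on these results. Still open, on these data alone, is whether a longer chain such as propyl on this nitrogen, or a carboxylic acid on the same ring, would move the number beyond the scatter.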